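A few compounds are considered here, and "the series" means these few. Any claim that something is new, unique, unknown or untested is made for them only; others in the source may bear on it.

Measured values, all in a functional assay on HCT-116 cells (Homo sapiens) for cytotoxicity, read by MTT assay, with a stated time of 72 h; a higher number here means a weaker inhibitor, a lower number a stronger inhibitor 
compound 1 `Nc1ccccc1NC(=O)c1ccc(NC(=S)NCc2ccc(Cl)nc2)cc1` gives 6100 nM 
compound 2 `Nc1ccccc1NC(=O)c1ccc(CNC(=O)c2cc3cnccc3[nH]2)cc1` gives 4000 nM 
compound 3 `Nc1ccccc1NC(=O)c1ccc(NC(=O)/C(Cl)=C(\Cl)c2cccnc2)cc1` gives 2400 nM 

Compound 1 and compound 2 lie within the scatter of each other. Compound 3 has a lower number than compound 1, and that gap lies beyond the scatter. Going by the values given here, the three measured compounds differ in more than one place, so the series offers no measured single-place step.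

Compound 4 `Cc1ccc(CNC(=S)Nc2ccc(C(=O)Nc3ccccc3N)cc2)cn1` is still to be measured. It keeps the structure of compound 1 except for one group, 6-chloropyridin-3-yl becoming 6-methylpyridin-3-yl, with methyl in place of chloro on an aromatic carbon next to the ring nitrogen (methyl in place of chloro on an aromatic carbon).

Among the compounds with values here, no measured pair shows this change, so the data give no direct size for it. No step beyond the scatter is expected, in either direction. The closest measured structure is compound 1 at 6100 nM and it serves as the anchor for the expectation. The estimated 1.1-fold lower number from compound 1 to compound 4 (0.04 log units; within the scatter) is expected to stay within the scatter. For compound 4 the expected value in this assay is 5500 nM with 2700 nM to 11000 nM as the estimated range.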

Compound 4, half-maximal inhibitory concentration: 11000 nM
For compound 4 the middle estimate is 2.0-fold (0.30 log units) below the measured one; low and high end bracket the measured number.
By their numbers in this assay, from the lowest: compounds 3, 2, 1 and 4 (each within the scatter of the next, the first and the last beyond it).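

In this assay, the series now has its first measured single-place step, a 1.8-fold higher number from compound 1 to compound 4 (0.26 log units; within the scatter), for methyl in place of chloro on an aromatic carbon next to the ring nitrogen and para to a large group. The change replaces one heavy atom with one heavy atom and leaves the counts of rings, hydrogen-bond donors, hydrogen-bond acceptors and net charge as they were, so this single pair gives no sign that the choice between these two groups at this position moves the read-out beyond the scatter. No supporting measurement bears on this result.

One pair cannot show whether other groups on this carbon, such as an amine, a methoxy group or a carboxylic acid, would stay within the scatter of compound 1 at 6100 nM. It also leaves open whether methyl in place of chloro would read the same way on a structure other than that of compound 1.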